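Swapping a Phenol for a Methoxyphenyl on a Sulfonamide

The compounds below may be only part of what the source reports. "The series", "measured", "known", "first", "only" and "open" are said of these compounds alone.

Measured so far:
- Compound 1 `COc1ccccc1S(=O)(=O)Nc1ccc2oc(-c3ccccc3)nc2c1`: in an assay on cells for inhibition of HSP60/HSP10 (Homo sapiens), with a stated time of 60 min (a higher number here means a weaker inhibitor, a lower number a stronger inhibitor), compound 1 gives only a limit of the assay, > 100000 nM.
- Compound 2 `O=S(=O)(Nc1ccc2oc(-c3ccccc3)nc2c1)c1ccc(O)cc1`: in this assay compound 2 gives 88000 nM.
- Compound 3 `O=S(=O)(Nc1ccc(-c2nc3ccccc3o2)cc1)c1ccc(O)cc1`: in this assay compound 3 gives 78000 nM.

All three compounds share a sulfonamide that links a substituted phenyl to a benzoxazole-bearing part; the way the cores of compound 2 and compound 3 are joined differs, but that difference is not broken down here. The values of compound 2 and compound 3 lie within the scatter of each other, so nothing separates them.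

Within the data shown here, the one change that has been measured is 2-methoxyphenyl in place of 4-hydroxyphenyl on a sulfonyl sulfur. It gave an at least 1.1-fold higher number from compound 2 to compound 1 (0.05 log units; that floor lies within the scatter). The size of that step is uncertain, since the limit of > 100000 nM in this assay, at which 1 of the 3 values shown sits, means only a floor is known for it.

Compound 4 `COc1ccccc1S(=O)(=O)Nc1ccc(-c2nc3ccccc3o2)cc1` is the not yet measured partner of compound 3. The change from compound 3 to compound 4 is 2-methoxyphenyl in place of 4-hydroxyphenyl on a sulfonyl sulfur, the same change at the same place as from compound 2 to compound 1.

The step is expected to be a 1.4-fold higher number from compound 3 to compound 4 (0.15 log units; within the scatter). That expectation rests on the measured step of an at least 1.1-fold higher number from compound 2 to compound 1 (0.05 log units; that floor lies within the scatter) and on the limit (the limit of > 100000 nM in this assay, at which 1 of the 3 values shown sits), which make a weak or unmeasurable inhibitor likely. Compound 4 is therefore estimated at 110000 nM in this assay. The expected range for compound 4 runs from 55000 nM to 250000 nM.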

Compound 4, half-maximal inhibitory concentration: > 100000 nM
Compound 4 ended at the assay's limit; the forecaster's own chance of this, stated with the estimate: 60%; the middle value does not contradict the limit.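

In this assay compound 4 gives > 100000 nM, which is a limit of the assay and not a number. Putting 2-methoxyphenyl in place of 4-hydroxyphenyl on the sulfonyl sulfur gave an at least 1.2-fold higher number from compound 3 to compound 4 (0.10 log units; that floor lies within the scatter), and a step of this kind is known only as a floor: the limit of > 100000 nM in this assay, at which 2 of the 4 values shown sit. Both compounds that carry 2-methoxyphenyl end at the limit, so the change brought no lower number on either core, but its true size on each core remains unknown, and the two steps cannot be called equal or different: the same change on two cores in this assay, an at least 1.1-fold higher number (0.05 log units; that floor lies within the scatter) from compound 2 to compound 1 and an at least 1.2-fold higher number (0.10 log units; that floor lies within the scatter) from compound 3 to compound 4; the limit leaves it open whether they differ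

From the compounds shown here alone, what other groups on the sulfonyl sulfur would do on these two cores stays open, for instance a phenyl ring carrying an amine or a carboxylic acid in place of the hydroxyl. Among these compounds, it is also open whether any such group could bring the number clearly lower than those of compound 2 at 88000 nM and compound 3 at 78000 nM, the only two compounds here with a value that is not a limit.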